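Butyl in place of pyrimidin-2-yl on a sulfur

This account rests on a few compounds, and the source may have more. Where it says the series, first, only, none or still open, it means among the compounds named here.

In a functional assay on MGC-803 cells (Homo sapiens) for cytotoxicity, read by MTT assay, with a stated time of 48 h (a lower number here means a stronger inhibitor, a higher number a weaker inhibitor), compound 3 `O=C(CSc1ncccn1)N1N=C(c2cc3ccccc3oc2=O)C[C@@H]1c1ccc(C(F)(F)F)cc1` gives 2890 nM. Among the measured compounds shown here, this is the lowest number so far, and it lies beyond the usual scatter from both other compounds. Compound 1 `CC1=NN(C(=O)CSc2ccccn2)[C@@H](c2cc(Br)cc(Br)c2O)C1` gives 12300 nM, and compound 2 `CC1=NN(C(=O)CSc2ccccc2)[C@@H](c2cc(Br)cc(Br)c2O)C1` gives 12700 nM.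

The next compound, compound 4 `CCCCSCC(=O)N1N=C(c2cc3ccccc3oc2=O)C[C@@H]1c1ccc(C(F)(F)F)cc1`, keeps the core of compound 3 and carries butyl in place of pyrimidin-2-yl on a sulfur. For the measured compounds named here, the one measured swap on a sulfur is a 1.0-fold higher number from compound 1 to compound 2 (0.01 log units; within the scatter), which stays within the scatter. That swap, phenyl in place of pyridin-2-yl, offers only weak guidance. Going by the values given here, it exchanges one ring for another on a different core, and no measured pair shows a ring giving way to an open chain.

A modest change is therefore expected, with real uncertainty about its direction: the estimated step is a 1.2-fold higher number from compound 3 to compound 4 (0.08 log units; within the scatter). For compound 4 the expected value is 3500 nM, with an estimated range from 1300 nM to 10000 nM.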

Compound 4, half-maximal inhibitory concentration: 2350 nM
Compound 4: middle estimate off by 1.5-fold (0.17 log units), on the high side; measured number inside the range.
By their numbers in this assay, from the lowest: compounds 4 and 3 (each within the scatter of the next); then compounds 1 and 2 (each within the scatter of the next).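

In this assay, the step is a 1.2-fold lower number from compound 3 to compound 4 (0.09 log units; within the scatter), so the two numbers cannot be told apart, even though an open butyl chain stands on the sulfur where compound 3 carries the pyrimidin-2-yl ring. The earlier swap on a sulfur only exchanged one ring for another, on a different core. This pair adds that, on the core of compound 3, the ring and its two hydrogen-bond acceptors can give way to a chain with none, without a readable difference in this cell assay.

A single chain cannot show how far this holds: a longer chain, a methyl group, or a butyl chain ending in an amine or a carboxylic acid could behave differently. On these data alone, it also remains open whether the same exchange would read alike on the core of compound 1. No measurement shown here offers an explanation for this result.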